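Chloro in Place of Fluoro: Expecting the Lipophilicity of Compound 4

The source may hold more compounds than are shown below. What is called first, only, known or untested is meant among the compounds shown, and "the series" means these compounds.

Compound 1 `Nc1nc(N)nc(-c2cccc(F)c2)n1` and compound 3 `Nc1nc(N)nc(-c2cccc(Cl)c2)n1` share a core and differ in one place: chloro in place of fluoro on an aromatic carbon In a physicochemical assay for lipophilicity (a higher number here means a more lipophilic compound, a lower number a more polar compound), compound 1 gives 1.73, and compound 3 gives 2.33. The step is a number 0.60 log units higher from compound 1 to compound 3 (beyond the scatter).

Compound 2 `Nc1nc(N)nc(-c2cc(Br)ccc2F)n1` carries a different core; how the cores of compound 1 and compound 2 differ is not broken down here. In this assay compound 2 gives 1.94, a number within the scatter of the number for compound 1, while compound 3 lies higher by an amount beyond the scatter.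

Compound 4 `Nc1nc(N)nc(-c2cc(Br)ccc2Cl)n1` has not yet been measured. It differs from compound 2 in one place: chloro in place of fluoro on an aromatic carbon This is the same kind of change as that from compound 1 to compound 3, but not the same, for the surroundings differ: in compound 3 the chloro sits meta to a group of 8 heavy atoms, whereas in compound 4 it sits ortho to a group of 8 heavy atoms and para to a bromo group.

In this assay a step of a number 0.56 log units higher from compound 2 to compound 4 (beyond the scatter) is expected, because the same kind of change gave a number 0.60 log units higher from compound 1 to compound 3 (beyond the scatter). The altered surroundings leave some room for the step to fall short of that earlier one. Compound 4 is therefore estimated at 2.5, expected to lie between 2.2 and 2.85.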

Compound 4, partition coefficient: 2.04
Compound 4: middle estimate off by 0.46 log units, on the high side, and the stated range ends above it.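

In this assay chloro in place of fluoro on an aromatic carbon gave a number 0.60 log units higher from compound 1 to compound 3 (beyond the scatter) on the one core but only a number 0.10 log units higher from compound 2 to compound 4 (within the scatter) on the other, so the size of the step did not carry over between these two cores. This shows that in this series a step seen on one core cannot be taken as a fixed increment for another, but two pairs give no general rule, and they do not show which difference in surroundings matters, whether the chloro in compound 4 being ortho to a group of 8 heavy atoms or its being para to a bromo group. Nothing shown here bears on why the two steps part.

The compounds shown carry only fluoro, chloro and bromo groups on the aromatic ring, which leaves open how any other group in the place of the fluoro would behave from core to core. A methoxy group, a nitrile or a carboxylic acid at that position could give steps that agree between the two cores or steps that part as these do, and the pairs shown cannot tell which.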